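Methyl on the sulfonyl aryl ring of the nitro cinnamoyl sulfonamide

The source may hold more compounds than are shown below. What is called first, only, known or untested is meant among the compounds shown, and "the series" means these compounds.

Among the measured compounds shown here, compound 2 `O=C(/C=C/c1ccc([N+](=O)[O-])cc1)NS(=O)(=O)c1ccccc1` gives 4.8 ug/mL in a functional assay on B16-F10 cells (Mus musculus) for antiproliferative activity, read by ELISA and MTT assay, with a stated time of 48 h (a lower number here means a stronger inhibitor, a higher number a weaker inhibitor), the lowest of the two numbers so far; compound 1 `COc1ccc(/C=C/C(=O)NS(=O)(=O)c2ccc(C)cc2)cc1` gives 12.2 ug/mL in this assay, a higher number, and the gap between them lies beyond the scatter. Compound 3 `Cc1ccc(S(=O)(=O)NC(=O)/C=C/c2ccc([N+](=O)[O-])cc2)cc1` is not yet measured in this assay. It differs from compound 2 by methyl in place of hydrogen on an aromatic carbon. For the measured compounds named here, no step of this kind between two measured compounds is available here, so the step from compound 2 to compound 3 is expected to be small, a 1.1-fold lower number from compound 2 to compound 3 (0.03 log units; within the scatter), with no direction beyond the scatter. Compound 3 is expected to give 4.5 ug/mL, within 2 ug/mL to 10 ug/mL.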

Compound 3, half-maximal inhibitory concentration: 13.5 ug/mL
Compound 3: the middle estimate sits 3.0-fold (0.48 log units) below what was measured, and the stated range ends below it.
By their numbers in this assay, from the lowest: compound 2; then compounds 1 and 3 (each within the scatter of the next).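

With the nitro group held fixed, phenyl to 4-methylphenyl is not a silent change in this assay: methyl in place of hydrogen gives a 2.8-fold higher number from compound 2 to compound 3 (0.45 log units; beyond the scatter) and so this aromatic carbon responds to a single added carbon. With 4-methylphenyl held fixed, nitro in place of methoxy gives a 1.1-fold higher number from compound 1 to compound 3 (0.04 log units; within the scatter) and so does not separate these two compounds. No measured evidence accounts for the methyl step. The compounds shown leave open whether chlorine, methoxy or a longer chain such as ethyl on this carbon behaves like methyl, and whether the methyl step carries over when methoxy replaces nitro.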